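Working notes: removal of the ring-nitrogen acyl group

The source may hold more compounds than are shown below. What is called first, only, known or untested is meant among the compounds shown, and "the series" means these compounds.

Measured compounds and values:
compound 1 `O=C(Nc1ccccc1O)C1CCc2ccccc2N1C(=O)c1ccc(Cl)cc1` — 25100 nM
compound 2 `O=C(Nc1ccccc1C(F)(F)F)C1CCc2ccccc2N1` — 53300 nM
compound 3 `CCCCCCCCC(=O)N1c2ccccc2CCC1C(=O)Nc1ccccc1O` — 45200 nM

In a functional assay on PC-3 cells (Homo sapiens) for cytotoxicity, read by sulforhodamine B assay, with a stated time of 72 h (on this read-out higher numbers stand for weaker inhibition of growth and lower numbers for stronger inhibition of growth), compound 3 stands second highest of the three numbers. Its nearest neighbour is compound 2, which in this assay gives 53300 nM, a gap within the scatter; its furthest is compound 1, which gives 25100 nM, also within the scatter. All three numbers therefore sit in one cluster with no order among them.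

The step to compound 4 `O=C(Nc1ccccc1O)C1CCc2ccccc2N1` is hydrogen in place of octylcarbonyl on a nitrogen on an aromatic ring in a ring. Within the data shown here, no measured step covers the loss of an acyl group from this nitrogen. Among the measured compounds shown here, the only step through one change is a 1.8-fold higher number from compound 1 to compound 3 (0.26 log units; within the scatter), which swaps one acyl group for another and stays within the scatter. Compound 2 carries a free ring nitrogen but differs from compound 3 in the anilide substituent as well, so its value only shows that a compound with the bare nitrogen lands in the same cluster.

With nothing pointing either way, a step for compound 4 within the scatter is expected, a 1.0-fold lower number from compound 3 to compound 4 (0.00 log units; within the scatter). Compound 4 is thus estimated at 45000 nM in this assay, with a range from 18000 nM to 110000 nM.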

Compound 4, concentration for 50% growth inhibition: 4310 nM
The estimate for compound 4 lay 10-fold (1.02 log units) above the measured number, outside the stated range (below it).
By their numbers in this assay, from the lowest: compound 4; then compounds 1, 3 and 2 (each within the scatter of the next, the first and the last beyond it).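

Earlier, the step between two acyl groups on this nitrogen stayed within the scatter (a 1.8-fold higher number from compound 1 to compound 3 (0.26 log units; within the scatter)), which gave no sign that the position mattered. In this assay, hydrogen on the nitrogen separates compound 4 from both acylated compounds, with octylcarbonyl leaving in one step (a 10-fold lower number from compound 3 to compound 4 (1.02 log units; beyond the scatter)) and (4-chlorophenyl)carbonyl in the other (a 5.8-fold lower number from compound 1 to compound 4 (0.77 log units; beyond the scatter)), so the position responds to losing the acyl group, whichever of these two it carries. Hydrogen on the nitrogen is not enough alone, since compound 2 also has it and still gives 53300 nM, and the step with hydroxy in place of trifluoromethyl on an aromatic carbon (a 12-fold lower number from compound 2 to compound 4 (1.09 log units; beyond the scatter)) shows that the lower number of compound 4 also depends on that substituent. Nothing at hand explains these steps.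

Still open, from the compounds shown here alone, is whether a smaller group on this nitrogen, such as acetyl or methyl, would keep the lower number, and whether an amine or a methoxy group could stand in for the hydroxy. Also open, going by these compounds, is how an acyl group on the nitrogen of compound 2 would move its number.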